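A few compounds are considered here, and "the series" means these few. Any claim that something is new, unique, unknown or untested is made for them only; others in the source may bear on it.

Compound 2 `O=C(N[C@@H](CO)C(=O)NO)c1ccc(C#Cc2ccccc2)cc1` gives 28000 nM in a physicochemical assay for solubility (on this read-out higher numbers stand for higher solubility and lower numbers for lower solubility), the highest of the three numbers: compound 1 `C#CCNC(=O)C[C@H](NC(=O)c1ccc(C#Cc2ccccc2)cc1)C(=O)NO` gives 8000 nM, and compound 3 `O=C(NC1(C(=O)NO)CCS(=O)(=O)CC1)c1ccc(C#Cc2ccccc2)cc1` gives 2000 nM. Compound 4 `NC(=O)C[C@H](NC(=O)c1ccc(C#Cc2ccccc2)cc1)C(=O)NO` differs from compound 2 by carbamoyl in place of hydroxy on a saturated chain carbon, two bonds along the chain from an amide-type nitrogen and a carbonyl carbon. Among the compounds with values here, one measured step bears on this: a 3.5-fold higher number from compound 1 to compound 2 (0.54 log units; beyond the scatter), where a hydroxy replaced a propargylcarbamoyl at that same place. Compound 4 runs the other way, putting a carbamoyl in place of the hydroxy, though the carbamoyl is smaller than the propargylcarbamoyl of compound 1, so a smaller fall than that step is expected. Compound 4 is therefore estimated at 15000 nM, in a range from 7000 nM to 30000 nM, which is expected to mean a 1.9-fold lower number from compound 2 to compound 4 (0.27 log units; within the scatter).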

Compound 4, solubility: 61000 nM
For compound 4 the middle estimate is 4.1-fold (0.61 log units) below the measured one, outside the stated range (above it).
By their numbers in this assay, from the lowest: compound 3; then compound 1; then compound 2; then compound 4.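

In this assay, carbamoyl at this place does not lower the number, as the propargylcarbamoyl of compound 1 did, but gives a 2.2-fold higher number from compound 2 to compound 4 (0.34 log units; beyond the scatter). The propargyl on the amide-type nitrogen therefore matters: hydrogen in its place gives a 7.6-fold higher number from compound 1 to compound 4 (0.88 log units; beyond the scatter), which puts compound 1 and compound 4 on opposite sides of the hydroxy compound 2. No measurement shown explains this change. Still open, from the compounds shown here alone, is whether an amine or a carboxylic acid at this place would stand with carbamoyl or with propargylcarbamoyl, and how a methyl on that nitrogen would read.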